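The source may hold more compounds than are shown below. What is called first, only, known or untested is meant among the compounds shown, and "the series" means these compounds.

Compound 1 `CNC(=O)N1CCCc2ccc(NC(=O)c3ccc(-c4ccn(C)n4)cc3)cc21` carries a 1-methyl-1H-pyrazol-3-yl group on the shared core. In a functional assay on MV4-11 cells (Homo sapiens) for antiproliferative activity, with a stated time of 6 days, tested at 1.56 uM (on this read-out higher numbers stand for a stronger effect at the one concentration tested and lower numbers for a weaker effect), compound 1 gives 72.2%, the highest of the three numbers shown, although it is separated from compound 3 only by a gap within the scatter. Compound 3 `CNC(=O)N1CCCc2ccc(NC(=O)c3cccc(-c4ccn(C)n4)c3)cc21` gives 70.5% in this assay. Compound 2 `CNC(=O)N1CCCc2ccc(NC(=O)c3ccccc3-c3ccccc3)cc21` gives 10.7%, a number far below compound 1 and well beyond the scatter. Compound 4 `CNC(=O)N1CCCc2ccc(NC(=O)c3ccc(-c4cnn(C)c4)cc3)cc21` has not yet been measured; it differs from compound 1 by the change (1-methyl-1H-pyrazol-4-yl in place of 1-methyl-1H-pyrazol-3-yl on an aromatic carbon). Among the measured compounds shown here, no measured pair shows a step of this kind, so its size is uncertain. Compound 4 is expected to give 58%, between 30% and 80%, a step of a number 14.2 percentage points lower from compound 1 to compound 4 (beyond the scatter) expected to be modest, probably downward and possibly within the scatter.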

Compound 4, a percentage reported as inhibition, at one concentration (the size of the read-out at that concentration, not a potency): 77.4%
Compound 4: middle estimate off by 19.4 percentage points, on the low side; measured number inside the range.
By their numbers in this assay, from the lowest: compound 2; then compounds 3, 1 and 4 (each within the scatter of the next).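

In this assay, putting 1-methyl-1H-pyrazol-4-yl in place of 1-methyl-1H-pyrazol-3-yl gives a number 5.2 percentage points higher from compound 1 to compound 4 (within the scatter), so at this place, para to a large group, the read-out does not tell the two ways of joining the same ring apart. This is the first pair shown that differs in one place only. Nothing measured here gives a reason for this result. Still open, from the compounds shown here alone, is whether an amine or a carboxylic acid at this place would hold the read-out at this level. Also open, going by these compounds, is what a longer chain in place of the methyl on the pyrazole would do.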